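The source may hold more compounds than are shown below. What is called first, only, known or untested is meant among the compounds shown, and "the series" means these compounds.

Values in a functional assay on HCT-116 cells (Homo sapiens) for antiproliferative activity, read by MTT assay, with a stated time of 48 h (on this read-out higher numbers stand for weaker inhibition and lower numbers for stronger inhibition), for the measured members of the series:
compound 1 `N#CC1=C(N)Oc2c(N)cc3nc4ccccc4nc3c2C12C(=O)N(Cc1cnnn1-c1ccccc1Br)c1ccccc12` gives 12400 nM.
compound 2 `Cc1cc(C)cc(-n2nncc2CN2C(=O)C3(C(C#N)=C(N)Oc4c(N)cc5nc6ccccc6nc5c43)c3ccccc32)c1` gives only a limit, > 50000 nM.
compound 3 `N#CC1=C(N)Oc2c(N)cc3nc4ccccc4nc3c2C12C(=O)N(Cc1cnnn1-c1c(F)cccc1F)c1ccccc12` gives only a limit, > 50000 nM.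

Compound 3 stands at the limit of this assay: its result is a limit and not a number, and it is one of the values that sit there (the limit of > 50000 nM in this assay, at which 2 of the 3 values shown sit). Of the three measured compounds only compound 1 gives a number.

The next step leads to compound 4 `N#CC1=C(N)Oc2c(N)cc3nc4ccccc4nc3c2C12C(=O)N(Cc1cnnn1-c1c(Cl)cc(Cl)cc1Cl)c1ccccc12`, with the change (2,4,6-trichlorophenyl in place of 2,6-difluorophenyl on an aromatic nitrogen).

The measured steps that bear on it are the two changes of the group on the aromatic nitrogen away from 2-bromophenyl: an at least 4.0-fold higher number from compound 1 to compound 2 (0.60 log units; beyond the scatter) and an at least 4.0-fold higher number from compound 1 to compound 3 (0.60 log units; beyond the scatter). Both end at the limit. The remaining step, a step that the two limits leave unreadable from compound 2 to compound 3, shows nothing about the size of a change between two groups that both sit at the limit.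

With compound 3 already at a limit, no step beyond the scatter can be read for compound 4 in either direction. The step of a number no higher from compound 3 to compound 4 (the limit leaves the size open) is expected to be small. Compound 4 is estimated at 50000 nM in this assay, with a range from 15000 nM to 200000 nM, and is expected most likely to be reported again as a limit.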

Compound 4, half-maximal inhibitory concentration: 12100 nM
Estimate against measurement, compound 4: 4.1-fold (0.62 log units) above; the whole stated range lies above it.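

In this assay, a measurable number on the aromatic nitrogen is not tied to 2-bromophenyl: 2,4,6-trichlorophenyl in place of 2,6-difluorophenyl gives an at least 4.1-fold lower number from compound 3 to compound 4 (0.61 log units; beyond the scatter), and in place of 3,5-dimethylphenyl it gives an at least 4.1-fold lower number from compound 2 to compound 4 (0.61 log units; beyond the scatter). Against the only earlier compound with a number, 2,4,6-trichlorophenyl in place of 2-bromophenyl gives a 1.0-fold lower number from compound 1 to compound 4 (0.01 log units; within the scatter), so the two groups cannot be told apart here, and in these four compounds the aryl groups with bromine or chlorine give numbers while those with fluorine or methyl give limits. The two steps down to compound 4 both start from limits, so their full size stays open: the limit of > 50000 nM in this assay, at which 2 of the 4 values shown sit.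

The compounds shown leave open whether the halogen itself or the number of substituents on the phenyl ring goes with the lower number; no compound here differs from compound 4 in a single chlorine. As far as these compounds go, how an unsubstituted phenyl, or a phenyl carrying an amine or a carboxylic acid, would read at this place on the triazole-type ring also stays open.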